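Trimming the aminopropyl chain back to methyl

This account rests on a few compounds, and the source may have more. Where it says the series, first, only, none or still open, it means among the compounds named here.

Among the measured compounds shown here, compound 2 `CN(C)CCCNc1nc(NCc2ccc(NC(=O)c3ccc(F)cc3)cc2)c2ccccc2n1` stands highest of the two numbers so far: in a functional assay on SW480 cells (Homo sapiens) for inhibition, read by luminescence and resazurin assay, with a stated time of 3 days (a lower number here means a stronger inhibitor, a higher number a weaker inhibitor), compound 2 gives 14000 nM, while compound 1 `CCCNc1nc(NCc2ccc(NC(=O)c3ccc(F)cc3)cc2)c2ccccc2n1` gives 2000 nM. For the measured compounds named here, the one step in hand is a 7.0-fold higher number from compound 1 to compound 2 (0.85 log units; beyond the scatter). Compound 3 `CNc1nc(NCc2ccc(NC(=O)c3ccc(F)cc3)cc2)c2ccccc2n1` goes the other way: hydrogen in place of 2-(dimethylamino)ethyl on a saturated chain carbon bound to a nitrogen on an aromatic ring, that is, (3-(dimethylamino)propyl)amino to methylamino. Going by the values given here, because a 7.0-fold higher number from compound 1 to compound 2 (0.85 log units; beyond the scatter) is the only step that bears on this change, and it moved in the weakening direction, a return toward the level of compound 1 is expected, about a 5.6-fold lower number from compound 2 to compound 3 (0.75 log units; beyond the scatter). Compound 3 is therefore estimated at 2500 nM, with a range of 800 nM to 8000 nM.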

Compound 3, half-maximal inhibitory concentration: 2000 nM
Compound 3: middle estimate off by 1.3-fold (0.10 log units), on the high side, and the stated range covers the measured number.
By their numbers in this assay, from the lowest: compounds 1 and 3 (each within the scatter of the next); then compound 2.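

In this assay, hydrogen in place of 2-(dimethylamino)ethyl gives a 7.0-fold lower number from compound 2 to compound 3 (0.85 log units; beyond the scatter), so the short methylamino group leaves behind the high number seen with the (3-(dimethylamino)propyl)amino chain. Hydrogen in place of ethyl at the same carbon gives no change at the digits printed from compound 1 to compound 3 (within the scatter), so among these three compounds only the chain bearing dimethylamino stands apart. Nothing at hand explains this difference. Going by these compounds, it remains open whether a terminal hydroxyl or carboxylic acid on the propyl chain would read like compound 2 or like compound 1. On these data alone, a longer plain alkyl chain is equally open.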